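The source may hold more compounds than are shown below. What is called first, only, known or untested is meant among the compounds shown, and "the series" means these compounds.

Measured in an ADME assay on MT4 cells (Homo sapiens) for cytotoxicity, read by MTT assay, with a stated time of 96 h; a higher number here means that more compound is tolerated, a lower number that less compound is tolerated:
- compound 1 `FC(F)(F)c1ccc(-c2nn(-c3ccccc3)cc2CNc2ccc(Cl)cc2)cc1`: > 100000 nM
- compound 2 `FC(F)(F)c1ccc(NCc2cn(-c3ccccc3)nc2-c2ccc(Br)cc2)cc1`: > 100000 nM

Both entries are limits of the assay and not numbers. Compound 2 stands at > 100000 nM in this assay, which is a limit, so its exact position is not known. The same holds across the small set: the limit of > 100000 nM in this assay, at which 2 of the 2 values shown sit.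

Compound 3 `FC(F)(F)c1ccc(NCc2cn(-c3ccccc3)nc2-c2ccc(C(F)(F)F)cc2)cc1` keeps the core of compound 2 and differs in one place, where the 4-bromophenyl becomes a 4-(trifluoromethyl)phenyl. This puts trifluoromethyl in place of bromo on an aromatic carbon, para to a large group (trifluoromethyl in place of bromo on an aromatic carbon).

Within the data shown here, no step between measured compounds is available to size such a change. The expectation therefore rests only on the two limits, and no shift beyond the usual scatter is expected in this assay, in either direction. The expected step of a number no higher from compound 2 to compound 3 (the limit leaves the size open) is thus small, and the assay may well report only a limit again. For compound 3 the estimated value is 100000 nM, with an expected range from 40000 nM to 200000 nM.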

Compound 3, half-maximal cytotoxic concentration: > 100000 nM
Compound 3: no number, only a limit; the forecaster's own chance of this, stated with the estimate: 75%; the middle value sits exactly at the limit.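

In this assay compound 3 gives > 100000 nM, which is a limit of the assay and not a number. The steps from compound 1 and compound 2 to compound 3 therefore cannot be read: the limit of > 100000 nM in this assay, at which 3 of the 3 values shown sit. The compounds shown leave open where each truly stands in this assay, and whether trifluoromethyl in place of bromo changes anything there.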